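Shifting Fluorine Positions on a Difluorophenyl Substituent

This account rests on a few compounds, and the source may have more. Where it says the series, first, only, none or still open, it means among the compounds named here.

compound 1: `Nc1scc(CN2CCN(c3cccnc3)CC2)c1C(=O)c1ccc(Cl)cc1` — 3.2%
compound 2: `Nc1scc(CN2CCN(c3ccc(F)cc3F)CC2)c1C(=O)c1ccc(Cl)cc1` — 0%

Of the compounds shown here, two sharing one core have been measured in a functional assay on CHO cells with adenosine receptor A1 (Homo sapiens) as the target, read by cAMP accumulation and immunoassay, with a stated time of 6 min, tested at 0.01 uM; a higher number here means a weaker effect of the compound at the concentration tested, a lower number a stronger effect. Compound 1, `Nc1scc(CN2CCN(c3cccnc3)CC2)c1C(=O)c1ccc(Cl)cc1`, gives 3.2% in this assay. Compound 2, `Nc1scc(CN2CCN(c3ccc(F)cc3F)CC2)c1C(=O)c1ccc(Cl)cc1`, gives 0%. Among the measured compounds shown here, the one measured step, a number 3.2 percentage points lower from compound 1 to compound 2 (within the scatter), is within the scatter, so the two numbers cannot be ordered. For the measured compounds named here, compound 2 stands at the lowest of the two numbers, with compound 1 as its only neighbour, a number a number 3.2 percentage points lower from compound 1 to compound 2 (within the scatter) higher, still within the scatter.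

The unmeasured compound 3, `Nc1scc(CN2CCN(c3c(F)cccc3F)CC2)c1C(=O)c1ccc(Cl)cc1`, differs from compound 2 in one place: 2,6-difluorophenyl in place of 2,4-difluorophenyl on an amine nitrogen in a ring. Going by the values given here, no measured step concerns a fluorine moved within a difluorophenyl group; the only step available exchanges the whole group on the amine nitrogen in a ring, and it produced nothing beyond the scatter. On that basis compound 3 is expected to show a step of about a number 1 percentage points higher from compound 2 to compound 3 (within the scatter) from compound 2 in this assay, that is, no change beyond the scatter. Compound 3 is therefore estimated at 1%, with a range from -8% to 12%.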

Compound 3, a percentage reported as activity, at one concentration (the size of the read-out at that concentration, not a potency): -12%
Beside the measured number, compound 3's estimate is 13 percentage points above it; the measured number lies below the stated range.
By their numbers in this assay, from the lowest: compound 3; then compounds 2 and 1 (each within the scatter of the next).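

In this assay, the change from 2,4-difluorophenyl to 2,6-difluorophenyl on an amine nitrogen in a ring gives a number 12 percentage points lower from compound 2 to compound 3 (beyond the scatter) with a stronger effect at the concentration tested, so the read-out at this position responds to the arrangement of the two fluorines, even though the leaving and entering groups have the same atoms and the same counts. Exchanging the whole group had earlier shown only a number 3.2 percentage points lower from compound 1 to compound 2 (within the scatter) for 2,4-difluorophenyl in place of pyridin-3-yl, whereas 2,6-difluorophenyl in place of pyridin-3-yl gives a number 15.2 percentage points lower from compound 1 to compound 3 (beyond the scatter) and so shows that an exchange at this nitrogen can move the number beyond the usual scatter. No information is available to explain why this fluorine arrangement differs from the other.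

The compounds shown leave open whether the change is particular to fluorine or would also appear with a phenyl group carrying two chlorine atoms or two methyl groups in their place. Each number is also a read-out at one concentration, so the size of any difference in potency among these compounds remains open.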